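The source may hold more compounds than are shown below. What is called first, only, known or untested is meant among the compounds shown, and "the series" means these compounds.

Measured so far in an ADME assay on microsomes from liver (Mus musculus) for metabolic stability, read by LC-MS, using NADPH, with stated times of 10 min and 30 min, tested at 1 uM; on this read-out higher numbers stand for fast clearance and lower numbers for slow clearance
compound 1 `COC(=O)C1=C(C)NC(c2nccs2)=NC1(C)c1ccc(Cl)cc1` at 85 mL/min/kg
compound 2 `COC(=O)C1=C(C)NC(c2nccs2)=NC1(C)c1ccc(C#N)cc1` at 75 mL/min/kg
compound 3 `COC(=O)C1=C(CN2CCC(F)(F)CC2)NC(c2nccs2)=NC1(C)c1ccc(F)cc1` at 88 mL/min/kg

Compound 3 at 88 mL/min/kg stands within the scatter of both compound 1 and compound 2, so these three numbers give no ranking. Next is compound 4 `COC(=O)C1=C(COC2CCOC2)NC(c2nccs2)=NC1(C)c1ccc(F)cc1` with (oxolan-3-yl)oxy in place of 4,4-difluoropiperidin-1-yl on a saturated chain carbon bound to a double-bonded ring carbon as the difference, which places (oxolan-3-yl)oxy in place of 4,4-difluoropiperidin-1-yl on a saturated chain carbon bound to a double-bonded ring carbon. Among the compounds with values here, the only measured step is a 1.1-fold lower number from compound 1 to compound 2 (0.05 log units; within the scatter) and it lies within the scatter. It concerns an aromatic carbon, so it is no direct guide to this exchange. In this assay no shift beyond the scatter is expected, with a 1.3-fold lower number from compound 3 to compound 4 (0.10 log units; within the scatter) as the estimated step. For compound 4 the estimated value is 70 mL/min/kg (expected range 40 mL/min/kg to 100 mL/min/kg).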

Compound 4, clearance: 79 mL/min/kg
Compound 4: the middle estimate sits 1.1-fold (0.05 log units) below what was measured; the range from low to high includes it.
By their numbers in this assay, from the lowest: compounds 2, 4, 1 and 3 (each within the scatter of the next).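

At the saturated chain carbon bound to a double-bonded ring carbon, (oxolan-3-yl)oxy in place of 4,4-difluoropiperidin-1-yl gives a 1.1-fold lower number from compound 3 to compound 4 (0.05 log units; within the scatter) in this assay. This position therefore accepts an exchange of the nitrogen-linked ring for an oxygen-linked ring with no shift beyond the scatter in this read-out. No other measurement bears on this result.

Going by these compounds, whether any group at this chain carbon can bring the number beyond the scatter remains open. A carboxylic acid or a primary amine there would test this.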